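Two aryl imides at the assay ceiling, a third awaited

The source may hold more compounds than are shown below. What is called first, only, known or untested is meant among the compounds shown, and "the series" means these compounds.

Compound 2 `COc1ccc(N2C(=O)[C@@H]3C(c4ccccc4)OC4(C(=O)c5ccccc5C4=O)[C@@H]3C2=O)cc1` has been tested in an assay on isolated protein for inhibition of phenylalanine--tRNA ligase, mitochondrial (Homo sapiens); a lower number here means a stronger inhibitor, a higher number a weaker inhibitor. There compound 2 gives > 100000 nM, which is a limit of the assay rather than a number. Its neighbour compound 1 `O=C1[C@@H]2C(c3ccccc3)OC3(C(=O)c4ccccc4C3=O)[C@@H]2C(=O)N1c1ccc(Cl)c(C(F)(F)F)c1` carries a different aryl group on the same ring nitrogen. In this assay compound 1 gives > 100000 nM, again a limit. The step that the two limits leave unreadable from compound 1 to compound 2 therefore cannot be read, since both ends sit at the limit of > 100000 nM in this assay, at which 2 of the 2 values shown sit. The unmeasured compound 3 `Cc1ccc(N2C(=O)[C@@H]3C(c4ccccc4)OC4(C(=O)c5ccccc5C4=O)[C@@H]3C2=O)cc1Cl` differs from compound 2 by 3-chloro-4-methylphenyl in place of 4-methoxyphenyl on an amide-type nitrogen in a ring. Among the compounds with values here, the only step bearing on it is the unreadable one between compound 1 and compound 2, so no size or direction can be drawn from the measured pair; both aryl variants gave limits. The step that the limit leaves unreadable from compound 2 to compound 3 is accordingly expected to leave compound 3 at the same ceiling. Compound 3 is estimated at 150000 nM, within 50000 nM to 500000 nM, most likely reported as a limit.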

Compound 3, half-maximal inhibitory concentration: > 100000 nM
Compound 3: only a limit was reported; the forecaster's own chance of this, stated with the estimate: 85%; the middle value does not contradict the limit.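

In this assay compound 3 also gives only a limit, so the steps to compound 3 from compound 1 and compound 2 cannot be read: the limit of > 100000 nM in this assay, at which 3 of the 3 values shown sit.

The compounds shown leave open whether changing the aryl group on the ring nitrogen of the shared core alters inhibition at all.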